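Phenyl for Methyl: Expected Outcome for Compound 4

The source may hold more compounds than are shown below. What is called first, only, known or untested is meant among the compounds shown, and "the series" means these compounds.

In a functional assay on the whole organism with Mus musculus as the target, with a stated time of 1 h (on this read-out lower numbers stand for an effect already at smaller amounts and higher numbers for an effect only at larger amounts of compound), three compounds have been measured:
compound 1 `CCCC/N=C(/C)Nc1nnc(-c2ccccc2C)s1` gives 46 mg/kg;
compound 2 `CCCC/N=C(/C)Nc1nnc(-c2ccccc2-c2ccccc2)s1` gives 90 mg/kg;
compound 3 `Cc1ccccc1-c1nnc(C2=NCCN2)s1` gives only a limit of the assay, > 200 mg/kg.

Compound 4 `c1ccc(-c2ccccc2-c2nnc(C3=NCCN3)s2)cc1` has not been measured. The change from compound 3 to compound 4 is phenyl in place of methyl on an aromatic carbon. The same change, (phenyl in place of methyl on an aromatic carbon), links compound 1 and compound 2, where it gave a 2.0-fold higher number from compound 1 to compound 2 (0.29 log units; within the scatter). The difference between the core of compound 1 and the core of compound 3 is not broken down here. Compound 3 sits at the limit of > 200 mg/kg in this assay, at which 1 of the 3 values shown sits. With the measured step within the scatter, compound 4 is expected to stay close to compound 3 and most likely to give only a limit again. The step from compound 3 is estimated as a step that the limit leaves unreadable from compound 3 to compound 4. Compound 4 is estimated at 300 mg/kg, between 150 mg/kg and 600 mg/kg.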

Compound 4, dose for half-maximal effect: 77 mg/kg
Compound 4: the middle estimate sits 3.9-fold (0.59 log units) above what was measured, and the stated range ends above it.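

In this assay, phenyl in place of methyl on an aromatic carbon did not behave alike on the two cores: the same change on two cores in this assay, a 2.0-fold higher number (0.29 log units; within the scatter) from compound 1 to compound 2 and an at least 2.5-fold lower number (0.41 log units; beyond the scatter) from compound 3 to compound 4, at least 5.0-fold (0.70 log units) apart, beyond the scatter of two such steps
Compound 3 gives > 200 mg/kg, which is a limit of the assay.
The change on this core reads as an at least 2.5-fold lower number from compound 3 to compound 4 (0.41 log units; beyond the scatter), and with phenyl kept, exchanging the other group gives a 1.2-fold lower number from compound 2 to compound 4 (0.07 log units; within the scatter); two cores do not show how the change would behave on a third, nor why the two steps differ.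

The compounds shown leave open whether an amine, a carboxylic acid or a longer chain in place of methyl or phenyl on that aromatic carbon would follow either step.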